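Swapping 4-hydroxyphenyl for 3-chlorophenyl on compound 2

A few compounds are considered here, and "the series" means these few. Any claim that something is new, unique, unknown or untested is made for them only; others in the source may bear on it.

Values measured in a functional assay on cells (Homo sapiens) for cytotoxicity, read by MTT assay, with a stated time of 24 h (on this read-out lower numbers stand for stronger inhibition and higher numbers for weaker inhibition), are these
- compound 1 `CCCCCCCCCCCCCCNC(=O)[C@H](CO)NCc1ccccc1O` gives 75300 nM
- compound 2 `CCCCCCCCCCCCCCNC(=O)[C@H](CO)/N=C/c1ccc(O)cc1` gives 19300 nM

Going by the values given here, of the two, compound 2 holds the lower number, and the only measured step runs a 3.9-fold lower number from compound 1 to compound 2 (0.59 log units; beyond the scatter) and is modest. Compound 3 `CCCCCCCCCCCCCCNC(=O)[C@H](CO)/N=C/c1cccc(Cl)c1` differs from compound 2 as follows 3-chlorophenyl in place of 4-hydroxyphenyl on a carbon with a double bond to nitrogen and so carries 3-chlorophenyl in place of 4-hydroxyphenyl on a carbon with a double bond to nitrogen. Among the compounds with values here, no measured step exchanges these two groups alone, so the step from compound 1 serves only as a rough yardstick of size, and it gives no direction. The estimated step is a 1.1-fold lower number from compound 2 to compound 3 (0.06 log units; within the scatter) and so none beyond the scatter is expected in this assay here. Compound 3 is expected at 17000 nM in this assay (estimated range 7000 nM to 45000 nM).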

Compound 3, half-maximal inhibitory concentration: 24100 nM
The estimate for compound 3 lay 1.4-fold (0.15 log units) below the measured number; the measured number falls inside the stated range.
By their numbers in this assay, from the lowest: compounds 2 and 3 (each within the scatter of the next); then compound 1.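

In this assay, 3-chlorophenyl in place of 4-hydroxyphenyl on a carbon with a double bond to nitrogen gives a 1.2-fold higher number from compound 2 to compound 3 (0.10 log units; within the scatter) and so shows that a group with no hydrogen-bond donor or acceptor can stand here with no change beyond the scatter. Compound 3 also keeps a modest edge over compound 1, with a 3.1-fold lower number from compound 1 to compound 3 (0.49 log units; beyond the scatter) as the step, so the two compounds carrying a double bond to nitrogen sit together on the lower side. Nothing available explains why these numbers fall as they do.

As far as these compounds go, whether an amine or a carboxylic acid on the ring would move the number beyond the scatter remains open. Also open, from the compounds shown here alone, is how much the chlorine and its place on the ring each contribute, as the group and its position change together here.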